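Series notes: from compound 1 to compound 3

The compounds below may be only part of what the source reports. "The series", "measured", "known", "first", "only" and "open" are said of these compounds alone.

For the measured compounds named here, compound 1 `CCCc1nnc([S+]([O-])Cc2ncc(C)c(OC)c2C)o1` gives 10000 nM in a functional assay on HUVEC cells (Homo sapiens) for inhibition, read by ELISA (on this read-out higher numbers stand for weaker inhibition and lower numbers for stronger inhibition), the highest of the two numbers measured so far. Compound 2 `[O-][S+](Cc1ccccc1)c1nnc(-c2cccnc2)o1` gives 8000 nM in this assay , a number that lies within the scatter of that of compound 1. Compound 3 `COc1c(C)cnc(C[S+]([O-])c2nnc(-c3cccc(F)c3)o2)c1C` differs from compound 1 by 3-fluorophenyl in place of propyl on an aromatic carbon. Going by the values given here, no step between measured compounds is known here; both measured compounds sit at weak inhibition, so the step of a 1.4-fold lower number from compound 1 to compound 3 (0.15 log units; within the scatter) is expected to be small, tending toward stronger inhibition but possibly not beyond the scatter. Compound 3 is therefore estimated at 7000 nM, within a range from 2500 nM to 20000 nM.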

Compound 3, half-maximal inhibitory concentration: 15000 nM
Beside the measured number, compound 3's estimate is 2.1-fold (0.33 log units) below it; the range from low to high includes it.
By their numbers in this assay, from the lowest: compounds 2, 1 and 3 (each within the scatter of the next).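

Putting 3-fluorophenyl in place of propyl on this aromatic carbon of the five-membered ring, with the rest of compound 1 kept, gives a 1.5-fold higher number from compound 1 to compound 3 (0.18 log units; within the scatter) in this assay. For the compounds shown here, this is the first step read at this position, and it shows that exchanging a small chain for a larger aromatic ring leaves the number within the scatter, with inhibition still weak. Nothing at hand bears on the reason for this result.

On these data alone, whether an amine, a carboxylic acid or a longer chain at this position would move the number beyond the scatter remains open. So does whether an unsubstituted phenyl would read the same as 3-fluorophenyl.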